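Solubility notes on an amide-nitrogen aryl exchange

The compounds below may be only part of what the source reports. "The series", "measured", "known", "first", "only" and "open" are said of these compounds alone.

Two compounds have results in a physicochemical assay for solubility, in phosphate buffer, measured as kinetic solubility, with a stated time of 1 h, at pH 7.4; a higher number here means a more soluble compound, a lower number a less soluble compound. Compound 1 `Cc1cc(C)cc(NC(=O)COc2cc(C)nc3ccc(OCc4ccccc4)cc23)c1` sits at a limit of that assay: its reading < 1000 nM is a limit and not a measured number, as recorded in the limit of < 1000 nM in this assay, at which 1 of the 2 values shown sits. Among the measured compounds shown here, compound 2 `COc1ccc(NC(=O)COc2cc(C)nc3ccc(OC)cc23)cc1` gives 108000 nM in this assay, the only plain number in the set, and therefore the only fixed point for comparison. Compound 3 `COc1ccc2nc(C)cc(OCC(=O)Nc3noc(C)c3C)c2c1` has not been measured yet; it differs from compound 2 by 4,5-dimethyl-1,2-oxazol-3-yl in place of 4-methoxyphenyl on an amide-type nitrogen. For the measured compounds named here, no step between two measured compounds is available, so the size of this change has to be expected rather than read off from data. The exchange is expected to leave solubility close to where compound 2 stands or move it up modestly, so the estimated step of a 1.4-fold higher number from compound 2 to compound 3 (0.14 log units; within the scatter) is small and positive, around the edge of the scatter. Compound 3 is expected at 150000 nM in this assay, with a range from 50000 nM to 400000 nM.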

Compound 3, solubility: 196000 nM
Compound 3: the middle estimate sits 1.3-fold (0.12 log units) below what was measured; the measured number falls inside the stated range.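

In this assay, among the compounds shown here, the exchange of 4-methoxyphenyl for 4,5-dimethyl-1,2-oxazol-3-yl on an amide-type nitrogen gives a 1.8-fold higher number from compound 2 to compound 3 (0.26 log units; within the scatter) as the first step that can be read at this position. A six-membered aromatic ring of carbon only and a five-membered aromatic ring with 2 hetero atoms cannot be told apart here by this read-out, so the group on this nitrogen need not be a phenyl ring for compound 3 to stand level with compound 2. Nothing shown bears on what lies behind this step.

From the compounds shown here alone, whether a group of another kind on this nitrogen, such as a chain ending in an amine or a phenyl ring carrying a carboxylic acid, would give a step beyond the scatter stays open. For the compounds shown here, compound 1 reads < 1000 nM as a limit of this assay and not a number, and no step to it can be read.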